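Methoxy for fluoro on a dihydrofolate reductase inhibitor

This account rests on a few compounds, and the source may have more. Where it says the series, first, only, none or still open, it means among the compounds named here.

Measured compounds:
compound 1 `NC1=NC2(CCOCC2)N(OCCCOc2ccc(F)cc2)C(N)=N1` — 46.6 nM
compound 2 `NC1=NC2(CCOCC2)N(OCCCOc2ccccc2Cl)C(N)=N1` — "not determined" (no result reported)

Among the compounds with values here, compound 1 is the only compound of this set with a number in an assay on isolated protein for inhibition of Dihydrofolate reductase (Homo sapiens), read by spectrophotometry, using NADPH, with stated times of 5 s and 6 min (a lower number here means a stronger inhibitor, a higher number a weaker inhibitor), where compound 1 gives 46.6 nM. Compound 2 carries a chloro in place of the fluoro, but in this assay compound 2 gives "not determined" (no result reported), so nothing can be said of how it compares. Within the data shown here, no step between two measured compounds is available to calibrate the change.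

Compound 3 `COc1ccc(OCCCON2C(N)=NC(N)=NC23CCOCC3)cc1` is the compound not yet measured. It differs from compound 1 by methoxy in place of fluoro on an aromatic carbon.

The step from compound 1 to compound 3 is expected to stay small and to lie within the scatter of this assay, or at most slightly toward a weaker inhibitor, since nothing measured here points in either direction; the expected change is a 1.3-fold higher number from compound 1 to compound 3 (0.11 log units; within the scatter). On that basis compound 3 is estimated in this assay at 60 nM, with a range from 20 nM to 180 nM.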

Compound 3, half-maximal inhibitory concentration: 11.1 nM
Compound 3: the middle estimate sits 5.4-fold (0.73 log units) above what was measured; the whole stated range lies above it.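

Within the data shown here, the exchange of 4-fluorophenyl for 4-methoxyphenyl gives a 4.2-fold lower number from compound 1 to compound 3 (0.62 log units; beyond the scatter) in this assay and so shows that a single substitution at this aromatic carbon, para to a large group, can move the result beyond the usual scatter, which no earlier pair of compounds could show. It also shows that the direction of this change is toward a stronger inhibitor, even though methoxy has more heavy atoms than fluoro and brings a hydrogen-bond acceptor that fluoro lacks. No measurement here accounts for the gain, and this one step cannot separate the contribution of the oxygen from that of the added carbon.

The compounds shown leave open whether the gain belongs to methoxy alone or would also appear with an ethoxy group, a hydroxyl or an amine on the same carbon. Among these compounds, they also leave open whether the same exchange would give a step of similar size if the shared core carried a longer chain in place of the one present in compound 1 and compound 3.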